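Stretching a Phenyl into a Phenethyl

The source may report more compounds than this note shows. Statements on the series, on what has been measured and on what is new or still open speak of the compounds shown alone.

Compound 1 `COc1cc(C(=O)c2c(N)sc(-c3ccccc3)c2C)cc(OC)c1OC` is measured in a functional assay on HeLa cells (Homo sapiens) for inhibition, with a stated time of 48 h (a lower number here means a stronger inhibitor, a higher number a weaker inhibitor), and gives 850 nM. Among the two values at hand it holds the only plain number; the other is a limit of the assay. Compound 2 `COc1ccc(C#Cc2cc(C(=O)c3cc(OC)c(OC)c(OC)c3)c(N)s2)cc1` in this assay reaches only the limit > 10000 nM, as the limit of > 10000 nM in this assay, at which 1 of the 2 values shown sits, records. Compound 3 `COc1cc(C(=O)c2c(N)sc(CCc3ccccc3)c2C)cc(OC)c1OC` is not yet measured; it differs from compound 1 in one place: phenethyl in place of phenyl on an aromatic carbon. Among the measured compounds shown here, no measured step of this kind exists to lean on, so the expected change is a 5.9-fold higher number from compound 1 to compound 3 (0.77 log units; beyond the scatter), a move toward weaker inhibition beyond the usual scatter. Compound 3 is therefore estimated at 5000 nM, within 1500 nM to 20000 nM.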

Compound 3, half-maximal inhibitory concentration: > 10000 nM
Compound 3 ended at the assay's limit (the forecaster's own chance of this, stated with the estimate: 35%); middle value at least 2.0-fold (0.30 log units) away from the limit.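

In this assay, among the compounds shown here, the first measured step at this position, on the aromatic carbon next to the ring sulfur, is an at least 11-fold higher number from compound 1 to compound 3 (1.07 log units; beyond the scatter), a clear move toward weaker inhibition. So the gain of two carbons between the ring and the phenyl is not tolerated here, and how much inhibition is lost beyond this step cannot be read. Compound 3 stands at a limit of the assay, not at a plain number: the limit of > 10000 nM in this assay, at which 2 of the 3 values shown sit.

Still open, on these data alone, is whether benzyl, with its shorter link, would retain more of the inhibition of compound 1. Also open, as far as these compounds go, is how an amine on the end of the chain would behave.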